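The compounds below may be only part of what the source reports. "The series", "measured", "known", "first", "only" and "open" are said of these compounds alone.

Measured so far in a functional assay on A549 cells (Homo sapiens) for antiproliferative activity, read by MTT assay, with a stated time of 48 h; on this read-out higher numbers stand for weaker inhibition and lower numbers for stronger inhibition:
Compound 1 `CC(=O)OC/C1=C/C[C@](C)(CCC=C(C)C)/C=C/[C@@H](OC(=O)C=C(C)C)[C@](C)(O)/C=C/C1=O`: 2950 nM
Compound 2 `CCN(CC)C/C1=C/C[C@](C)(CCC=C(C)C)/C=C/[C@@H](OC(=O)C=C(C)C)[C@](C)(O)/C=C/C1=O`: 130 nM
Compound 3 `CSC(=S)OC/C1=C/C[C@](C)(CCC=C(C)C)/C=C/[C@@H](OC(=O)C=C(C)C)[C@](C)(O)/C=C/C1=O`: 380 nM

Compound 3 stands second highest of the three numbers, with a 2.9-fold higher number from compound 2 to compound 3 (0.47 log units; beyond the scatter) on one side and a 7.8-fold lower number from compound 1 to compound 3 (0.89 log units; beyond the scatter) on the other. From compound 3 to compound 4 `CC(C)=CCC[C@]1(C)/C=C/[C@@H](OC(=O)C=C(C)C)[C@](C)(O)/C=C/C(=O)/C(C(=O)N(C(C)C)C(C)C)=C\C1` the change is a group of 9 heavy atoms (7 carbon, 1 nitrogen, 1 oxygen; no ring) in place of a group of 6 heavy atoms (3 carbon, 1 oxygen, 2 sulfur; no ring), on a double-bonded ring carbon. The entering diisopropylcarbamoyl sits on a double-bonded ring carbon, whereas all three measured compounds carry their variable group on a saturated chain carbon bound to a double-bonded ring carbon. Among the measured compounds shown here, no measured step covers this change directly. The nearest guides are a 23-fold lower number from compound 1 to compound 2 (1.36 log units; beyond the scatter) and the two steps above, all at this same part of the molecule. Together they show the span that replacements here have produced in this assay. For the measured compounds named here, compound 3 lies toward the lower end of that span, and the data hold no carbamoyl example. A modest rise is therefore expected, though a step within the scatter cannot be excluded. The step expected is a 2.1-fold higher number from compound 3 to compound 4 (0.32 log units; beyond the scatter). For compound 4 the estimated value is 800 nM, with an expected range of 200 nM to 3500 nM.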

Compound 4, half-maximal inhibitory concentration: 13500 nM
Beside the measured number, compound 4's estimate is 17-fold (1.23 log units) below it; the whole stated range lies below it.
By their numbers in this assay, from the lowest: compound 2; then compound 3; then compound 1; then compound 4.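

In this assay, diisopropylcarbamoyl on the double-bonded ring carbon comes with a 36-fold higher number from compound 3 to compound 4 (1.55 log units; beyond the scatter) and a 100-fold higher number from compound 2 to compound 4 (2.02 log units; beyond the scatter) and also a 4.6-fold higher number from compound 1 to compound 4 (0.66 log units; beyond the scatter), so compound 4 carries the highest number of the four. Among the compounds shown here, the span of numbers at this part of the molecule therefore reaches further upward than the earlier compounds showed, and acetoxymethyl in compound 1 no longer marks its top. Compound 2 and compound 4 both carry a nitrogen in the group at this place yet stand at opposite ends of the span, so a nitrogen in this group does not by itself go with a low number, and nothing available here accounts for the size of these steps.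

The compounds shown leave open whether the higher number follows the carbonyl attached directly to the ring carbon or the two isopropyl groups on nitrogen, since the steps to compound 4 change both together. A diethylcarbamoyl group at the same ring carbon or a (diisopropylamino)methyl group would separate the two, and a carboxylic acid there would show whether the carbonyl alone goes with a high number.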